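Bromo to 3-fluoropropyl on a dimethoxy-substituted benzamide

The compounds below may be only part of what the source reports. "The series", "measured", "known", "first", "only" and "open" are said of these compounds alone.

Of the compounds shown here, two have been measured in a physicochemical assay for lipophilicity, at pH 7.4; on this read-out higher numbers stand for higher lipophilicity and lower numbers for lower lipophilicity. Compound 1 `C=CCN1CCC[C@H]1CNC(=O)c1cc(CCCF)ccc1OC` gives 2.63 in this assay. For the measured compounds named here, compound 2 `C=CCN1CCC[C@H]1CNC(=O)c1cc(Br)cc(OC)c1OC` gives 2.83 in this assay, and the two numbers lie within the scatter of each other, so neither can be set above the other; the two structures differ in more than one place, and no single step between them is counted. Compound 3 `C=CCN1CCC[C@H]1CNC(=O)c1cc(CCCF)cc(OC)c1OC` carries the change (3-fluoropropyl in place of bromo on an aromatic carbon), that is, 3-fluoropropyl in place of bromo on an aromatic carbon. For this change the expected step is small, with no clear direction beyond the scatter, the estimated step being a number 0.02 log units higher from compound 2 to compound 3 (within the scatter). On that basis compound 3 is expected to give 2.85 in this assay, with a range from 2.4 to 3.3.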

Compound 3, distribution coefficient: 2.66
Beside the measured number, compound 3's estimate is 0.19 log units above it; the measured number falls inside the stated range.
By their numbers in this assay, from the lowest: compounds 1, 3 and 2 (each within the scatter of the next).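

In this assay, for the compounds shown here, putting 3-fluoropropyl in place of bromo on this aromatic carbon gives a number 0.17 log units lower from compound 2 to compound 3 (within the scatter) on the shared core, so exchanging one heavy atom for four leaves no step that can be told from the scatter at this position. The added methoxy group, in place of hydrogen on an aromatic carbon, can now be read as a single change too, and it gives a number 0.03 log units higher from compound 1 to compound 3 (within the scatter) in the same read-out of this assay with 3-fluoropropyl in place. No measurement at hand offers an explanation for either step. From the compounds shown here alone, each change rests on a single pair of compounds, so whether it would read the same on another core stays open. Also open, going by these compounds, is how this assay would respond at this position to an amine, a carboxylic acid or a chain longer than 3-fluoropropyl.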